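Aryl Substitution on the Furan Ester of Compound 3

The source may hold more compounds than are shown below. What is called first, only, known or untested is meant among the compounds shown, and "the series" means these compounds.

Measured so far:
Compound 1 `CCOc1cc(C(=O)OCc2ccc(-c3ccc(C)cc3)o2)cc(OCC)c1OCC`: 16.4%
Compound 2 `COc1cc(COC(=O)c2ccco2)cc(OC)c1OC`: 10%
Compound 3 `COc1cc(COC(=O)c2ccc(C)o2)cc(OC)c1OC`: -9.9%

In an assay on isolated protein for inhibition of high affinity 3',5'-cyclic-AMP phosphodiesterase 7A (Homo sapiens), read by scintillation proximity assay and cAMP accumulation, with a stated time of 20 min, tested at 10 uM (a higher number here means more inhibition at the concentration tested (going by the name of the read-out), a lower number less inhibition), compound 3 gives the lowest of the three numbers, beyond the scatter from both others. The step of a number 19.9 percentage points lower from compound 2 to compound 3 (beyond the scatter) shows that adding a methyl on the furan lowered the read-out. Compound 4 `COc1cc(COC(=O)c2ccc(-c3ccc(Cl)cc3Cl)o2)cc(OC)c1OC` carries 2,4-dichlorophenyl in place of methyl on an aromatic carbon. Among the compounds with values here, no measured step matches this change on the shared core; compound 1, with an aryl group on the furan but a different core, gives a modest positive value, which is the only hint available. Compound 4 is therefore expected to rise modestly, with a number 19.9 percentage points higher from compound 3 to compound 4 (beyond the scatter), to an estimated 10% (range -10% to 30%).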

Compound 4, a percentage reported as inhibition, at one concentration (the size of the read-out at that concentration, not a potency): 38.3%
Beside the measured number, compound 4's estimate is 28.3 percentage points below it; the whole stated range lies below it.
By their numbers in this assay, from the lowest: compound 3; then compounds 2 and 1 (each within the scatter of the next); then compound 4.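

In this assay, 2,4-dichlorophenyl on this aromatic carbon, next to the ring oxygen, gives a number 48.2 percentage points higher from compound 3 to compound 4 (beyond the scatter), so the shared core accepts a much larger group here than methyl. Against hydrogen the change gives a number 28.3 percentage points higher from compound 2 to compound 4 (beyond the scatter), which shows that the read-out at this place can go up as well as down, depending on the group. No evidence on hand accounts for this rise. From the compounds shown here alone, whether the two chlorines matter, and how a plain phenyl or a phenyl carrying an amine or a carboxylic acid would compare, stays open.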